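Methoxyphenyl for methylphenyl on two related cores

The compounds below may be only part of what the source reports. "The series", "measured", "known", "first", "only" and "open" are said of these compounds alone.

Measured so far:
compound 1 `Cc1ccc(-c2cccc(COc3ccc(CCC(=O)O)cc3)c2)cc1` gives 490 nM
compound 2 `Cc1ccc(-c2cccc(CNc3ccc(CCC(=O)O)cc3)c2)cc1` gives 126 nM
compound 3 `COc1ccccc1-c1cccc(COc2ccc(CCC(=O)O)cc2)c1` gives 120 nM

All three values come from a functional assay on 1321-N1 cells for agonist activity at Free fatty acid receptor 1 (Homo sapiens), read by calcium flux; on this read-out higher numbers stand for an effect only at larger amounts of compound and lower numbers for an effect already at smaller amounts. The difference between the core of compound 1 and the core of compound 2 is not broken down here. Compound 3 differs from compound 1 by 2-methoxyphenyl in place of 4-methylphenyl on an aromatic carbon, and this change gave a 4.1-fold lower number from compound 1 to compound 3 (0.61 log units; beyond the scatter). Compound 2 and compound 3 stand within the scatter of each other in this assay.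

Compound 4 `COc1ccccc1-c1cccc(CNc2ccc(CCC(=O)O)cc2)c1` has not yet been measured. It carries the same change relative to compound 2: 2-methoxyphenyl in place of 4-methylphenyl on an aromatic carbon. Going by the values given here, the step from compound 2 to compound 4 is expected to be a 3.2-fold lower number from compound 2 to compound 4 (0.50 log units; beyond the scatter); this expectation rests on compound 1 and compound 3, because a 4.1-fold lower number from compound 1 to compound 3 (0.61 log units; beyond the scatter) is the only example of the change seen so far. For compound 4 the estimated value is 40 nM, with a range from 15 nM to 120 nM.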

Compound 4, half-maximal effective concentration: 69.2 nM
Estimate against measurement, compound 4: 1.7-fold (0.24 log units) below, and the stated range covers the measured number.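

On the core of compound 2, 2-methoxyphenyl in place of 4-methylphenyl gave a 1.8-fold lower number from compound 2 to compound 4 (0.26 log units; within the scatter) in this assay. Set beside the earlier step, the two cores cannot be told apart for this change: the same change on two cores in this assay, a 4.1-fold lower number (0.61 log units; beyond the scatter) from compound 1 to compound 3 and a 1.8-fold lower number (0.26 log units; within the scatter) from compound 2 to compound 4, 2.2-fold (0.35 log units) apart, within the scatter of two such steps. This shows that the two steps agree as far as the scatter allows, but it does not show that the change carries over with a fixed size, and the step on the core of compound 2, taken alone, lies within the scatter.

The change alters both the substituent and its place on the ring, and the compounds shown do not separate the two. Also open, from the compounds shown here alone, is how an ethoxy group or a chlorine on that phenyl ring would behave on either core.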